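The source may hold more compounds than are shown below. What is called first, only, known or untested is meant among the compounds shown, and "the series" means these compounds.

Measured so far in an in vitro functional assay on 1321-N1 cells for agonist activity at P2Y purinoceptor 6 (Homo sapiens), read by scintillation proximity assay and inositol phosphate accumulation; a lower number here means that less compound is needed, a higher number that more compound is needed for the effect:
compound 1, `Nc1nc(=O)ccn1[C@@H]1O[C@H](COP(=O)(O)OP(=O)(O)O)[C@@H](O)[C@H]1O`: >= 100000 nM
compound 2, `O=c1[nH]c(=S)ccn1[C@@H]1O[C@H](COP(=O)(O)O)[C@@H](O)[C@H]1O`: > 100000 nM
compound 3, `COc1nc(=O)ccn1[C@@H]1O[C@H](COP(=O)(O)O)[C@@H](O)[C@H]1O`: 9800 nM

Compound 1 has no number in this assay, only a limit, >= 100000 nM; this is the limit of >= 100000 nM in this assay, at which 1 of the 3 values shown sits. Compound 2 likewise sits at a limit, > 100000 nM, which is the limit of > 100000 nM in this assay, at which 1 of the 3 values shown sits. Going by the values given here, compound 3 is the one compound of the three with a measured number, 9800 nM. Among the compounds with values here, compounds 1 and 3 share neither the same phosphate chain nor the same group on the shared core, so their two values show only that compound 3 gives a number where compound 1 gives a limit.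

Compound 4, `O=c1ccn([C@@H]2O[C@H](COP(=O)(O)OP(=O)(O)O)[C@@H](O)[C@H]2O)c(SCCc2ccccc2)n1`, is the next compound, not yet measured. Relative to compound 1 the change is phenethylsulfanyl in place of amino on an aromatic carbon. Within the data shown here, no pair of measured compounds differs in a single place, so the size of this step has no measured counterpart. The expectation is a step toward less compound needed, large enough to move from the limit into the measurable range rather than a change within the scatter. The step from compound 1 to compound 4 is estimated at an at least 50-fold lower number from compound 1 to compound 4 (1.69 log units; beyond the scatter). For compound 4 the expected value in this assay is 2000 nM, with a range from 300 nM to 20000 nM.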

Compound 4, half-maximal effective concentration: 2500 nM
For compound 4 the middle estimate is 1.3-fold (0.10 log units) below the measured one; the range from low to high includes it.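

Going by these compounds alone, with phenethylsulfanyl in place of amino on the aromatic carbon between two ring nitrogen atoms, this assay shows an at least 40-fold lower number from compound 1 to compound 4 (1.60 log units; beyond the scatter), the only step that can be read at a single place. Compound 1 stands at a limit, not a number, so this step is a lower bound on the change: the limit of >= 100000 nM in this assay, at which 1 of the 4 values shown sits. With the phosphate chain unchanged, this position therefore accepts a group of 9 heavy atoms with a six-membered aromatic ring of carbon only and 0 hydrogen-bond donors, and amino at this carbon is not needed for a measured response.

The sulfur, the two-carbon chain and the aromatic ring enter together, and the compounds shown do not separate their shares in the step. As far as these compounds go, a methylsulfanyl group, a phenethylamino group or a longer chain on the same carbon would each divide the step, and the effect of a chlorine or methoxy group on the aromatic ring of the phenethylsulfanyl group remains equally open.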